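The source may report more compounds than this note shows. Statements on the series, on what has been measured and on what is new or still open speak of the compounds shown alone.

Three compounds have been measured in a functional assay on T47D cells (Homo sapiens) for cytotoxicity, read by CCK-8 assay and cell counting, with a stated time of 2 days; on this read-out higher numbers stand for weaker inhibition and lower numbers for stronger inhibition:

Compound 1 `Oc1cccc(-c2cc(-c3ccc(Cl)cc3)nc(-c3cccs3)c2)c1` gives 10500 nM
Compound 2 `Oc1cccc(-c2cc(-c3cccs3)nc(-c3ccccc3Cl)c2)c1` gives 3990 nM
Compound 3 `Oc1cccc(-c2cc(-c3cccc(Cl)c3)nc(-c3cccs3)c2)c1` gives 3410 nM

Compound 2 stands second highest of the three numbers. Its nearest neighbour is compound 3, since a 1.2-fold lower number from compound 2 to compound 3 (0.07 log units; within the scatter); its furthest is compound 1, since a 2.6-fold lower number from compound 1 to compound 2 (0.42 log units; beyond the scatter). The only differences among the measured compounds are in where the chlorine sits on its phenyl ring: a 3.1-fold lower number from compound 1 to compound 3 (0.49 log units; beyond the scatter) and a 2.6-fold lower number from compound 1 to compound 2 (0.42 log units; beyond the scatter), both modest, and a 1.2-fold lower number from compound 2 to compound 3 (0.07 log units; within the scatter).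

Compound 4 `Oc1cccc(-c2cc(-c3ccccc3)nc(-c3ccccc3Cl)c2)c1` differs from compound 2 in one place: phenyl in place of thiophen-2-yl on an aromatic carbon. Within the data shown here, none of the measured steps touches this group; all three keep the thiophen-2-yl and move only the chlorine. There is therefore no step among these compounds that bears on the change, and the best guide is the number of compound 2 itself, with a wide margin on either side. The expected step in this assay is a 1.0-fold higher number from compound 2 to compound 4 (0.00 log units; within the scatter), which is none beyond the scatter. For compound 4 the estimate is 4000 nM, with a range from 1300 nM to 12000 nM.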

Compound 4, half-maximal inhibitory concentration: 2920 nM
Beside the measured number, compound 4's estimate is 1.4-fold (0.14 log units) above it; measured number inside the range.
By their numbers in this assay, from the lowest: compounds 4, 3 and 2 (each within the scatter of the next); then compound 1.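

In this assay, putting phenyl in place of the thiophen-2-yl next to the ring nitrogen gives no change beyond the scatter (a 1.4-fold lower number from compound 2 to compound 4 (0.14 log units; within the scatter)). Among these compounds, the earlier steps moved only the chlorine, so this is the first reading at this position, and it shows that, with the 2-chlorophenyl group in place, a six-membered aromatic ring of carbon only can stand here in place of the five-membered sulfur-containing ring with no shift beyond the scatter. Nothing available gives a reason for this result.

As far as these compounds go, whether the same holds with the chlorine on the 3-chlorophenyl or 4-chlorophenyl group remains open. Also open, from the compounds shown here alone, is how this position would respond to a group other than an aromatic ring, such as an amine or a carboxylic acid.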